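The compounds below may be only part of what the source reports. "The series", "measured", "known", "first", "only" and "open" are said of these compounds alone.

Measured in an ADME assay on J774.A1 cells (Mus musculus) for cytotoxicity; on this read-out lower numbers stand for higher toxicity in this test and higher numbers for lower toxicity in this test:
- compound 1 `Fc1ccc(N2CCN(c3nc(-n4ccc5ccccc54)c4ccccc4n3)CC2)cc1`: 23.4 ug/mL
- compound 2 `COc1ccc(-c2nc(N3CCNCC3)nc3ccccc23)c(OC)c1`: 3.98 ug/mL
- compound 3 `COc1cc(OC)c(-c2nc(N3CCN(C)CC3)nc3ccccc23)c(OC)c1`: > 100 ug/mL (a limit of the assay, not a number)

Compound 3 gives no number, only the limit > 100 ug/mL. The series data record this as the limit of > 100 ug/mL in this assay, at which 1 of the 3 values shown sits. Its true position is therefore open on the high side, and any step starting from compound 3 can be sized only roughly.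

The next compound is compound 4 `COc1ccc(-c2nc(N3CCN(C)CC3)nc3ccccc23)c(OC)c1`. It has hydrogen in place of methoxy on an aromatic carbon, ortho to a large group and meta to two methoxy groups (hydrogen in place of methoxy on an aromatic carbon).

Going by the values given here, no measured pair differs in one place, so no direct precedent exists for this change in this assay. The expected direction is towards a lower number, meaning higher toxicity in this test, with a step probably beyond the usual scatter. This expectation rests on the two numerical results, compound 1 at 23.4 ug/mL and compound 2 at 3.98 ug/mL.

The expected change is an at least 2.8-fold lower number from compound 3 to compound 4 (0.45 log units; beyond the scatter), and this size remains uncertain. For compound 4 the estimate is 35 ug/mL, with an expected range of 10 ug/mL to 100 ug/mL.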

Compound 4, half-maximal cytotoxic concentration: 18 ug/mL
Beside the measured number, compound 4's estimate is 1.9-fold (0.29 log units) above it, and the stated range covers the measured number.
By their numbers in this assay, from the lowest: compound 2; then compounds 4 and 1 (each within the scatter of the next). At a limit, above all of these: compound 3.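

In this assay, going by these compounds alone, hydrogen in place of methoxy on the aromatic carbon ortho to a large group and meta to two methoxy groups gives an at least 5.5-fold lower number from compound 3 to compound 4 (0.74 log units; beyond the scatter) and so provides the first direct reading at this position. This step starts from a limit of the assay for compound 3, and its size is therefore only a lower bound: the limit of > 100 ug/mL in this assay, at which 1 of the 4 values shown sits. Methyl in place of hydrogen on an amine nitrogen in a ring gives a 4.5-fold higher number from compound 2 to compound 4 (0.66 log units; beyond the scatter) and shows that a second site also moves this read-out, with both single changes shown, the added methoxy and the added methyl, going towards a higher number.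

As far as these compounds go, at the aromatic carbon, only methoxy and hydrogen can be compared here, so it remains open whether fluorine, chlorine or a hydroxyl group there would give a number closer to that of compound 3 or compound 4. From the compounds shown here alone, on the ring nitrogen, only hydrogen and methyl are covered, and the effect of an ethyl group or a longer chain in this assay remains open.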